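This account rests on a few compounds, and the source may have more. Where it says the series, first, only, none or still open, it means among the compounds named here.

Three compounds share one core and differ only in the aryl group attached to a carbon with a double bond to nitrogen. Compound 1 `CN(C)CCn1cnnc1-c1cc(Oc2ccc(NC(=O)N/N=C/c3cccc(O)c3)cc2F)ccn1` gives 780 nM in a functional assay on NCI-H460 cells (Homo sapiens) for cytotoxicity, read by MTT assay, with a stated time of 72 h; on this read-out higher numbers stand for weaker inhibition and lower numbers for stronger inhibition; compound 2 `CN(C)CCn1cnnc1-c1cc(Oc2ccc(NC(=O)N/N=C/c3cccc(Cl)c3Cl)cc2F)ccn1` gives 72 nM in this assay; compound 3 `CN(C)CCn1cnnc1-c1cc(Oc2ccc(NC(=O)N/N=C/c3ccc(O)c(F)c3)cc2F)ccn1` gives 2620 nM in this assay, the highest number of the three. The two steps that end at compound 3 show how strongly this aryl group moves the read-out: a 3.4-fold higher number from compound 1 to compound 3 (0.53 log units; beyond the scatter), and a 36-fold higher number from compound 2 to compound 3 (1.56 log units; beyond the scatter). Compound 4 `CN(C)CCn1cnnc1-c1cc(Oc2ccc(NC(=O)N/N=C/c3c[nH]c4ccccc34)cc2F)ccn1` has not yet been measured. It differs from compound 3 in one place: 1H-indol-3-yl in place of 3-fluoro-4-hydroxyphenyl on a carbon with a double bond to nitrogen. Within the data shown here, no measured step involves an indolyl group, so the two steps into compound 3 only set the span: the group that leaves is the one that gave the highest number, and every other aryl group measured on this carbon gave a lower one. A lower number is therefore expected for compound 4, with wide uncertainty. Compound 4 is expected to give about 400 nM in this assay, between 100 nM and 1800 nM. The estimated step is a 6.6-fold lower number from compound 3 to compound 4 (0.82 log units; beyond the scatter).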

Compound 4, half-maximal inhibitory concentration: 1630 nM
For compound 4 the middle estimate is 4.1-fold (0.61 log units) below the measured one, within the range that was stated.
By their numbers in this assay, from the lowest: compound 2; then compound 1; then compounds 4 and 3 (each within the scatter of the next).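

In this assay, 1H-indol-3-yl in place of 3-fluoro-4-hydroxyphenyl gives a 1.6-fold lower number from compound 3 to compound 4 (0.21 log units; within the scatter), so these two groups cannot be told apart at this carbon, even though one has a single ring and the other two. Compared with the remaining groups, the indolyl group gives a 2.1-fold higher number from compound 1 to compound 4 (0.32 log units; beyond the scatter) and a 23-fold higher number from compound 2 to compound 4 (1.35 log units; beyond the scatter), which shows that a group without a hydroxyl can also sit far above the 2,3-dichlorophenyl compound. No measurement at hand explains these differences.

The compounds shown leave open whether a phenyl ring carrying one chlorine, rather than two, would come close to compound 2 at 72 nM on this read-out. On these data alone, it is also open whether a methyl group on the indole nitrogen would change the number seen for compound 4.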